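Compound 3 and the cycloheptyl swap

The compounds below may be only part of what the source reports. "The series", "measured", "known", "first", "only" and "open" are said of these compounds alone.

Values in an ADME assay on MRC5 cells (Homo sapiens) for inhibition, with a stated time of 72 h; a higher number here means that more compound is needed for the effect, a lower number that less compound is needed:
compound 1 `COc1cccc(OC)c1C(=O)Nc1c[nH]nc1C(=O)NC1CC2CCC1C2`: > 50000 nM
compound 2 `COc1cccc(OC)c1C(=O)Nc1c[nH]nc1C(=O)NC1CCCCCC1`: 42000 nM

Compound 1 gives a reading of > 50000 nM, which is a limit of the assay and not a number. For the measured compounds named here, that leaves compound 2 with the only actual number in this assay, at 42000 nM. Compound 3 `COc1cccc(OC)c1C(=O)Nc1c[nH]nc1C(=O)Nc1ccncc1` differs from it by pyridin-4-yl in place of cycloheptyl on an amide-type nitrogen, which places pyridin-4-yl in place of cycloheptyl on an amide-type nitrogen. Going by the values given here, one measured step bears on this position, an at least 1.1-fold lower number from compound 1 to compound 2 (0.07 log units; that floor lies within the scatter). It exchanges one carbon-only ring system for another, so it offers only a weak guide to a ring containing nitrogen. With that limited support, no change beyond the scatter is expected in this assay. The expected step is a 1.1-fold higher number from compound 2 to compound 3 (0.03 log units; within the scatter). For compound 3, the estimated value is 45000 nM, with an expected range of 20000 nM to 100000 nM.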

Compound 3, half-maximal effective concentration: > 50000 nM
Compound 3 gave a limit, no number (the forecaster's own chance of this, stated with the estimate: 55%); middle value at least 1.1-fold (0.04 log units) away from the limit.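

In this assay, pyridin-4-yl in place of cycloheptyl on an amide-type nitrogen gives an at least 1.1-fold higher number from compound 2 to compound 3 (0.07 log units; that floor lies within the scatter). This adds an aromatic ring with a nitrogen to the carbon-only rings seen at this position, yet it yields no readable number, and the step from compound 1 to compound 3 cannot be read since both values are limits. The limit now accounts for most of the readings: the limit of > 50000 nM in this assay, at which 2 of the 3 values shown sit.

The compounds shown leave open how far the true values of compound 1 and compound 3 lie from that limit, and so how large the change to pyridin-4-yl really is. They also leave open whether a plain phenyl ring or a piperidin-4-yl group on this nitrogen would give a number clearly different from that of compound 2.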